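A few compounds are considered here, and "the series" means these few. Any claim that something is new, unique, unknown or untested is made for them only; others in the source may bear on it.

Measured in a functional assay on the whole organism with Rattus norvegicus as the target, with a stated time of 4 h, at a dose of 40 mg/kg by the intraperitoneal route; a higher number here means more inhibition at the dose given (going by the name of the read-out), a lower number less inhibition:
compound 1 `Cc1nc2c(OCc3ccccc3)cccn2c1CCC#N`, 40%
compound 2 `COCc1c(C)nc2c(OCc3ccccc3)cccn12`, 99%
compound 3 `COC(=O)Cc1c(C)nc2c(OCc3ccccc3)cccn12`, 23%

Compound 2 stands highest of the three numbers in this assay. The nearest is compound 1, at 40%. The furthest is compound 3, at 23%. Both steps from compound 2 are beyond the scatter: a number 59 percentage points higher from compound 1 to compound 2 (beyond the scatter) and a number 76 percentage points lower from compound 2 to compound 3 (beyond the scatter).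

Compound 4 `Cc1nc2c(OCc3ccccc3)cccn2c1COC(=O)C(C)(C)C` is not yet measured. It differs from compound 2 in one place: (tert-butyl)carbonyl in place of methyl on an oxygen on a saturated carbon. The step that bears most on it is a number 76 percentage points lower from compound 2 to compound 3 (beyond the scatter), where a carbonyl enters on the saturated chain carbon bound to an aromatic carbon and the number falls a long way; here a carbonyl also enters, though the ether oxygen of compound 2 is kept, so the parallel is only partial. The step of a number 59 percentage points higher from compound 1 to compound 2 (beyond the scatter) shows that changes at this chain carbon move the number strongly in either direction. A downward step beyond the scatter is therefore expected, but smaller than the fall to compound 3. The expected step is a number 39 percentage points lower from compound 2 to compound 4 (beyond the scatter). Compound 4 is estimated at 60% in this assay, within 25% to 95%.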

Compound 4, a percentage reported as inhibition, in the whole organism at one dose (the size of the read-out at that dose, not a potency): 48%
Estimate against measurement, compound 4: 12 percentage points above; measured number inside the range.
By their numbers in this assay, from the lowest: compound 3; then compounds 1 and 4 (each within the scatter of the next); then compound 2.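

In this assay, keeping the oxygen on the saturated carbon does not keep the number high once (tert-butyl)carbonyl replaces methyl on it (a number 51 percentage points lower from compound 2 to compound 4 (beyond the scatter)), so the top reading of the series depends on what that oxygen carries and not on the oxygen alone. The two carbonyl-bearing groups also give different readings at the saturated chain carbon bound to an aromatic carbon (a number 25 percentage points higher from compound 3 to compound 4 (beyond the scatter)), while ((tert-butyl)carbonyl)oxy and cyanomethyl cannot be told apart there (a number 8 percentage points higher from compound 1 to compound 4 (within the scatter)). No evidence in hand explains these differences.

As far as these compounds go, whether a small acetyl group on the same oxygen, or a free hydroxyl in its place, would read closer to compound 2 or to compound 4 remains open. From the compounds shown here alone, an amine at the chain carbon is equally open.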